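The source may report more compounds than this note shows. Statements on the series, on what has been measured and on what is new or still open speak of the compounds shown alone.

Measured compounds:

Compound 1, `COc1ccc(/C=C/C(=O)c2ccc(N)c(-c3ccc(F)cc3)c2)cc1OC`, gives 3780 nM.
Compound 2, `O=C(/C=C/c1cccc(-c2ccc(F)cc2)c1)c1ccc(O)cc1`, gives 5120 nM.
Compound 3, `COc1ccc(-c2cc(C(=O)/C=C/c3cc(OC)c(OC)c(OC)c3)ccc2N)cc1OC`, gives 2680 nM.

These three were characterised in a functional assay on HepG2 cells (Homo sapiens) for cytotoxicity, read by sulforhodamine B assay, with a stated time of 48 h; a lower number here means a stronger inhibitor, a higher number a weaker inhibitor. Among them compound 3 carries the lowest number, but its gap to compound 1 and its gap to compound 2 both lie within the scatter, so the three compounds cannot be set in any order on this evidence. Within the data shown here, no pair among them differs in only one place, so no single structural step has been measured.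

Compound 4, `COc1cc(/C=C/C(=O)c2ccc(N)c(-c3ccc(F)cc3)c2)cc(OC)c1OC`, is the next compound and has not yet been measured in this assay. It is compared with compound 3. The change is 4-fluorophenyl in place of 3,4-dimethoxyphenyl on an aromatic carbon; the 4-fluorophenyl enters on an aromatic carbon ortho to an amino group and meta to a large group. Compound 1 already carries a 4-fluorophenyl at that place and gives a number close to compound 3, so for compound 4 only a small step is expected, a 1.3-fold higher number from compound 3 to compound 4 (0.12 log units; within the scatter), not beyond the scatter. Compound 4 is estimated at 3500 nM, between 1500 nM and 8000 nM.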

Compound 4, half-maximal inhibitory concentration: 4210 nM
Estimate against measurement, compound 4: 1.2-fold (0.08 log units) below, within the range that was stated.
By their numbers in this assay, from the lowest: compounds 3, 1, 4 and 2 (each within the scatter of the next).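

In this assay, among these compounds, 4-fluorophenyl in place of 3,4-dimethoxyphenyl, on the aromatic carbon ortho to an amino group, gives a 1.6-fold higher number from compound 3 to compound 4 (0.20 log units; within the scatter), the first single-place reading at this position, and on this evidence the two groups cannot be told apart there. The second single-place reading, methoxy in place of hydrogen on an aromatic carbon, gives a 1.1-fold higher number from compound 1 to compound 4 (0.05 log units; within the scatter), so this change also cannot be told from repeat measurement. No measurement is available that would explain either result.

The compounds shown carry only substituted phenyl groups at this position, so it remains open whether an unsubstituted phenyl, a pyridine ring or a small chain such as ethyl would shift the number beyond the scatter. Also open, from the compounds shown here alone, is what would follow if a hydroxyl or an acetamide replaced the amino group.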